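This account rests on a few compounds, and the source may have more. Where it says the series, first, only, none or still open, it means among the compounds named here.

Measured so far:
compound 1, `COc1ccc(C2=NN(C3=NC(=O)/C(=C4\C(=O)Nc5ccc(Br)cc54)S3)C(c3ccc(OC)cc3)C2)cc1`, in a functional assay on cells (Melanoma cell, Homo sapiens) for cytotoxicity, read by sulforhodamine B assay, with a stated time of 48 h (a lower number here means a stronger inhibitor of growth, a higher number a weaker inhibitor of growth), compound 1 gives 190 nM
compound 2, `COc1ccc(C2=NN(C3=NC(=O)/C(=C4\C(=O)Nc5ccccc54)S3)C(c3ccc(Cl)cc3)C2)cc1`, in this assay compound 2 gives 100000 nM

Of the two measured compounds, compound 2 stands at the higher number, and its gap to compound 1 lies beyond the scatter of this assay; the two structures differ in two places at once, so the measured pair alone does not tell how much of that gap belongs to either place.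

Compound 3, `COc1ccc(C2=NN(C3=NC(=O)/C(=C4\C(=O)Nc5ccc(Br)cc54)S3)C(c3ccc(Cl)cc3)C2)cc1`, has not been measured. It arises from compound 2 by a single change, (bromo in place of hydrogen on an aromatic carbon), so that compound 3 now shares the bromo group of compound 1 and differs from compound 1 only elsewhere. Going by the values given here, no single-change step between measured compounds is available to anchor this move. Still, compound 1, which carries the bromo group, sits far lower than compound 2, and it is expected that compound 3 will move a sizeable way in the same downward direction, a step of a 50-fold lower number from compound 2 to compound 3 (1.70 log units; beyond the scatter). Compound 3 is therefore estimated at 2000 nM, within a range from 200 nM to 40000 nM.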

Compound 3, concentration for 50% growth inhibition: 160 nM
Beside the measured number, compound 3's estimate is 13-fold (1.10 log units) above it; the whole stated range lies above it.
By their numbers in this assay, from the lowest: compounds 3 and 1 (each within the scatter of the next); then compound 2.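

In this assay, bromo in place of hydrogen on an aromatic carbon of the fused system of two rings gives a large step on its own (a 630-fold lower number from compound 2 to compound 3 (2.80 log units; beyond the scatter)), something the earlier pair could not show, as its two structures differed in two places at once. The second place can now be read separately: with the bromo group present, chloro in place of methoxy on an aromatic carbon gives a step within the scatter (a 1.2-fold lower number from compound 1 to compound 3 (0.07 log units; within the scatter)), so in this pair the two groups cannot be told apart by their numbers, and most of the gap between compound 1 and compound 2 falls to the bromo position. Nothing measured here offers an explanation for the size of the bromo step.

From the compounds shown here alone, whether fluoro, a methyl group, an amine or a carboxylic acid on that same aromatic carbon would give a step of similar size remains open. Also open is whether chloro and methoxy would still match with hydrogen in place of bromo, as compound 2 is the only compound shown with hydrogen there.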